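The source may hold more compounds than are shown below. What is called first, only, known or untested is meant among the compounds shown, and "the series" means these compounds.

The series shares one core and is varied only at the aryl group on the carbonyl carbon. Compound 1 `COc1ccc(-c2cc3ccccc3nc2/C=C/C(=O)c2ccccc2)cc1` carries a plain phenyl there, and in a functional assay on NCI-H1299 cells (Homo sapiens) for antiproliferative activity, read by XTT assay, with a stated time of 72 h (a lower number here means a stronger inhibitor, a higher number a weaker inhibitor), compound 1 gives 1410 nM. Compound 2 `COc1ccc(-c2cc3ccccc3nc2/C=C/C(=O)c2ccc(OC)c(OC)c2)cc1` carries a 3,4-dimethoxyphenyl instead, and in this assay compound 2 gives 1050 nM, the lower of the two numbers, though the gap to compound 1 is within the scatter. Among the measured compounds shown here, the only step measured so far, a 1.3-fold lower number from compound 1 to compound 2 (0.13 log units; within the scatter), is small.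

Compound 3 `COc1ccc(-c2cc3ccccc3nc2/C=C/C(=O)c2ccc(N)cc2)cc1` has not yet been measured. It differs from compound 2 by 4-aminophenyl in place of 3,4-dimethoxyphenyl on a carbonyl carbon. The step that bears on this change is a 1.3-fold lower number from compound 1 to compound 2 (0.13 log units; within the scatter), which shows that exchanging the aryl group on the carbonyl carbon changed little. For the measured compounds named here, no measured compound carries an amino group, so nothing in these data points to a direction for this exchange. On that basis the expected step is a 1.1-fold lower number from compound 2 to compound 3 (0.02 log units; within the scatter), which is not expected to go beyond the scatter. The estimate for compound 3 in this assay is 1000 nM, within a range from 400 nM to 2500 nM.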

Compound 3, half-maximal inhibitory concentration: 6510 nM
Estimate against measurement, compound 3: 6.5-fold (0.81 log units) below; measured number outside the range, above it.
By their numbers in this assay, from the lowest: compounds 2 and 1 (each within the scatter of the next); then compound 3.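

In this assay the aryl group on the carbonyl carbon proves not to be indifferent: the exchange of phenyl for 3,4-dimethoxyphenyl stayed within the scatter, whereas 4-aminophenyl brings a 6.2-fold higher number from compound 2 to compound 3 (0.79 log units; beyond the scatter) when it replaces 3,4-dimethoxyphenyl and a 4.6-fold higher number from compound 1 to compound 3 (0.66 log units; beyond the scatter) when it replaces the plain phenyl. Both steps lie beyond the scatter and run the same way, so this position can respond to the aryl group it carries, and amino in place of hydrogen on an aromatic carbon is by itself enough to separate compound 3 from compound 1. The data shown offer no measured explanation for this result.

The compounds shown leave open whether the higher number belongs to the amino group in particular or would also appear with a hydroxyl, a single methoxy, an acetamide or a dimethylamino group on the same phenyl ring. They also leave open whether a carboxylic acid or a halogen such as fluorine at this position would move the number in the same direction, or whether the step seen with compound 3 is specific to the amino group.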